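Adding a Third Methoxy Group on a Cinnamamide Side Chain

The compounds below may be only part of what the source reports. "The series", "measured", "known", "first", "only" and "open" are said of these compounds alone.

Measured compounds:
compound 1, `COc1ccc(/C=C/C(=O)Nc2cc3c(Nc4ccc(F)c(Cl)c4)ncnc3cc2O[C@H]2CCOC2)c(OC)c1`: 2760 nM
compound 2, `COc1ccc(/C=C/C(=O)Nc2cc3c(Nc4ccc(F)c(Cl)c4)ncnc3cc2O[C@H]2CCOC2)c(OC)c1OC`: 7670 nM
compound 3, `COc1cc(/C=C/C(=O)Nc2cc3c(Nc4ccc(F)c(Cl)c4)ncnc3cc2OC)cc(OC)c1`: "not active" (no number reported)

In a functional assay on PC-3 cells (Homo sapiens) for cytotoxicity, read by MTT assay, with a stated time of 72 h (a lower number here means a stronger inhibitor, a higher number a weaker inhibitor), compound 1 gives 2760 nM, and compound 2 gives 7670 nM. The change between them is methoxy in place of hydrogen on an aromatic carbon, and it produced a 2.8-fold higher number from compound 1 to compound 2 (0.44 log units; beyond the scatter). Compound 3 reported "not active" (no number reported) in this assay, so no number is available for it. Compound 4, `COc1cc2ncnc(Nc3ccc(F)c(Cl)c3)c2cc1NC(=O)/C=C/c1cc(OC)c(OC)c(OC)c1`, is not yet measured; it carries the same kind of change, (methoxy in place of hydrogen on an aromatic carbon), on the core of compound 3, differing from the earlier one in that the new group sits para rather than meta to a large group. How the cores of compound 1 and compound 3 differ is not broken down here. Since compound 3 gave no number and the earlier step weakened potency, compound 4 is expected to be inactive or weak, estimated near 30000 nM, plausibly between 8000 nM and 100000 nM.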

Compound 4, half-maximal inhibitory concentration: 38200 nM
Compound 4: middle estimate off by 1.3-fold (0.10 log units), on the low side; the range from low to high includes it.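

Within the data shown here, compound 3 has no number in this assay, so no step to compound 4 can be read. Whether the added methoxy strengthens or weakens activity on this core stays open, and no measurement here bears on the cause.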